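The compounds below may be only part of what the source reports. "The series", "measured", "known", "first", "only" and "open" are said of these compounds alone.

Measured compounds:
compound 1, `COc1ccc(C2=NNC(c3c(Cl)cccc3Cl)C2)cc1OC`, 49%
compound 2, `COc1ccc(C2=NN(C(=O)CBr)C(c3c(Cl)cccc3Cl)C2)cc1OC`, 58%
compound 3, `COc1ccc(C2=NN(C(=O)C(C)Br)C(c3ccco3)C2)cc1OC`, 36%

These three were tested in a functional assay on the whole organism (strain albino) for inhibition, with Rattus norvegicus as the target, read by paw edema, with stated times of 30 min and 2 h, at a dose of 100 mg/kg by the oral route; a higher number here means more inhibition at the dose given (going by the name of the read-out), a lower number less inhibition. Compound 3 stands lowest of the three: its gap to compound 1 and its larger gap to compound 2 both lie beyond the usual scatter of this measurement. Compound 4, `COc1ccc(C2=NN(C(=O)C(C)Br)C(c3c(Cl)cccc3Cl)C2)cc1OC`, has not yet been measured. It arises from compound 3 by one change, (2,6-dichlorophenyl in place of furan-2-yl on a saturated ring carbon), while the (1-bromoethyl)carbonyl group on the ring nitrogen is kept.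

Among the compounds with values here, only one step between measured compounds is known, a number 9 percentage points higher from compound 1 to compound 2 (within the scatter), and it concerns the group on the ring nitrogen, not the group that is exchanged here. Within the data shown here, no measured pair shows the swap of furan-2-yl for 2,6-dichlorophenyl directly. What the numbers do show is that both compounds bearing 2,6-dichlorophenyl, compound 1 and compound 2, sit well above compound 3, and compound 4 will share that group and the acyl substitution pattern of compound 2. Compound 4 is therefore expected to lie closer to compound 2 than to compound 3, a step of a number 18 percentage points higher from compound 3 to compound 4 (beyond the scatter) beyond the scatter. The estimate for compound 4 in this assay is 54%, with a range from 40% to 66%.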

Compound 4, a percentage reported as inhibition, in the whole organism at one dose (the size of the read-out at that dose, not a potency): 56%
For compound 4 the middle estimate is 2 percentage points below the measured one, and the stated range covers the measured number.
By their numbers in this assay, from the lowest: compound 3; then compounds 1, 4 and 2 (each within the scatter of the next).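

In this assay, the exchange on the saturated ring carbon can now be read directly, with the (1-bromoethyl)carbonyl group on the ring nitrogen held fixed: 2,6-dichlorophenyl in place of furan-2-yl gives a number 20 percentage points higher from compound 3 to compound 4 (beyond the scatter). With 2,6-dichlorophenyl kept, changes on the acyl side give no step beyond the scatter: methyl in place of hydrogen on the chain carbon bound to bromine gives a number 2 percentage points lower from compound 2 to compound 4 (within the scatter), and the full (1-bromoethyl)carbonyl group in place of hydrogen on the ring nitrogen gives a number 7 percentage points higher from compound 1 to compound 4 (within the scatter), so among these single changes only the exchange on the ring carbon stands out from the scatter. Nothing available accounts for the size of that step.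

Within the data shown here, the exchange is seen with only one group on the ring nitrogen, so it remains open whether furan-2-yl and 2,6-dichlorophenyl would stand as far apart with hydrogen or (bromomethyl)carbonyl there. The compounds shown also leave open what a plain phenyl or a pyridine ring would give on the ring carbon, and what an amine in place of the bromine on the acyl chain would give.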